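The compounds below may be only part of what the source reports. "The series", "measured", "known", "first", "only" and "open" are said of these compounds alone.

Measured so far in a functional assay on U-937 cells (Homo sapiens) for cytotoxicity, read by MTT assay, with a stated time of 24 h; on this read-out lower numbers stand for stronger inhibition and higher numbers for weaker inhibition:
compound 1 `COc1ccccc1N1CCN(CCCCCOc2c(Br)cc(Br)cc2Oc2ccc(Br)cc2Br)CC1`, 37.5 ug/mL
compound 2 `Brc1ccc(Oc2cc(Br)cc(Br)c2OCCCCCN2CCN(C/C=C/c3ccccc3)CC2)c(Br)c1`, 32.7 ug/mL
compound 3 `COc1c(Br)cc(Br)cc1Oc1ccc(Br)cc1Br`, 34.5 ug/mL

On these numbers compound 2 sits alongside compound 3 and compound 1, with all three values inside the scatter of one another. Compound 4 `CC(C)(C)OC(=O)N1CCN(CCCCCOc2c(Br)cc(Br)cc2Oc2ccc(Br)cc2Br)CC1` is compound 2 with one change: tert-butoxycarbonyl in place of 3-phenylprop-2-en-1-yl on an amine nitrogen in a ring.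

Among the compounds with values here, the only measured step that bears on this place, a 1.1-fold lower number from compound 1 to compound 2 (0.06 log units; within the scatter), swapped one group on the same ring nitrogen and moved the read-out by nothing beyond the scatter. Within the data shown here, no measured pair shows a tert-butoxycarbonyl group, so its effect is unknown. The step from compound 2 to compound 4 is therefore expected to be a 1.1-fold higher number from compound 2 to compound 4 (0.03 log units; within the scatter), no larger than the scatter. For compound 4 the estimate in this assay is 35 ug/mL, expected to lie between 18 ug/mL and 70 ug/mL.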

Compound 4, half-maximal inhibitory concentration: 35.5 ug/mL
Estimate against measurement, compound 4: 1.0-fold (0.01 log units) below; the measured number falls inside the stated range.
By their numbers in this assay, from the lowest: compounds 2, 3, 4 and 1 (each within the scatter of the next).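

In this assay, a third group on the ring nitrogen leaves the read-out within the scatter, with a 1.1-fold higher number from compound 2 to compound 4 (0.04 log units; within the scatter) and a 1.1-fold lower number from compound 1 to compound 4 (0.02 log units; within the scatter). Tert-butoxycarbonyl has no ring and 2 hydrogen-bond acceptors, whereas 3-phenylprop-2-en-1-yl has a six-membered aromatic ring and 0 acceptors, yet this difference produces no change beyond the scatter. No evidence is available to explain this result.

The compounds shown leave open whether a free secondary amine at this nitrogen, or a carboxylic acid on its substituent, would shift the read-out beyond the scatter. They also leave open the effect of a shorter chain linking this nitrogen to the shared core.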